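The source may hold more compounds than are shown below. What is called first, only, known or untested is meant among the compounds shown, and "the series" means these compounds.

Of the compounds shown here, three built on the same core have been measured in an assay (Rattus norvegicus) for inhibition of Fatty-acid amide hydrolase 1 (Homo sapiens); on this read-out higher numbers stand for weaker inhibition and lower numbers for stronger inhibition. Compound 1 `O=C(CCCCCCc1ccccc1)c1ncc(-c2ccc(F)cc2)o1` carries a 4-fluorophenyl group on the core and gives 62 nM. Compound 2 `NC(=O)c1ccc(-c2cnc(C(=O)CCCCCCc3ccccc3)o2)nc1` gives 1.2 nM, and compound 3 `NS(=O)(=O)c1ccc(-c2cnc(C(=O)CCCCCCc3ccccc3)o2)s1` gives 3 nM. Compound 3 thus holds the second highest of the three numbers: its nearest neighbour is compound 2, since a 2.5-fold higher number from compound 2 to compound 3 (0.40 log units; beyond the scatter), while the furthest is compound 1, since a 21-fold lower number from compound 1 to compound 3 (1.32 log units; beyond the scatter).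

The next compound, compound 4 `O=C(CCCCCCc1ccccc1)c1ncc(-c2ncccn2)o1`, differs from compound 3 in one place: pyrimidin-2-yl in place of 5-sulfamoylthiophen-2-yl on an aromatic carbon. The two steps that bear on this change are the ones leading out of compound 1, where a 52-fold lower number from compound 1 to compound 2 (1.71 log units; beyond the scatter) and a 21-fold lower number from compound 1 to compound 3 (1.32 log units; beyond the scatter); in each case a group with a hydrogen-bond donor replaced 4-fluorophenyl and the number fell by a large amount. Compound 4 drops such a group and carries a plain pyrimidin-2-yl instead, so the expectation is that much of that drop is given back and the number rises in this assay by a large step, an 8.3-fold higher number from compound 3 to compound 4 (0.92 log units; beyond the scatter), though not all the way to compound 1. Compound 4 is therefore estimated at 25 nM, with a range from 5 nM to 120 nM.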

Compound 4, inhibition constant: 5.3 nM
The estimate for compound 4 lay 4.7-fold (0.67 log units) above the measured number; the measured number falls inside the stated range.
By their numbers in this assay, from the lowest: compound 2; then compounds 3 and 4 (each within the scatter of the next); then compound 1.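

Pyrimidin-2-yl, with 0 hydrogen-bond donors, still gives a far lower number than 4-fluorophenyl in this assay (a 12-fold lower number from compound 1 to compound 4 (1.07 log units; beyond the scatter)), so at this place on the shared core a large fall does not depend on a group that carries a hydrogen-bond donor. Pyrimidin-2-yl also cannot be told apart from 5-sulfamoylthiophen-2-yl (a 1.8-fold higher number from compound 3 to compound 4 (0.25 log units; within the scatter)), even though it has 6 heavy atoms against 9 and a six-membered aromatic ring instead of a five-membered one, so this place tolerates quite different groups with no clear loss. Among the compounds shown here, only 5-carbamoylpyridin-2-yl keeps a real edge over pyrimidin-2-yl (a 4.4-fold higher number from compound 2 to compound 4 (0.65 log units; beyond the scatter)), which makes it the one group here that stands apart from the others at the low end of the scale.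

Nothing shown here explains why these groups rank as they do. A plain phenyl or an unsubstituted pyridin-2-yl at this place would help show whether the fall from compound 1 follows the ring nitrogens, the loss of the fluorine, or both, and a primary amide on the pyrimidine would test whether the edge of compound 2 carries over to this ring.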